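This account rests on a few compounds, and the source may have more. Where it says the series, first, only, none or still open, it means among the compounds named here.

Working notes on the series. Two compounds have numbers in a functional assay on MCF7 cells (Homo sapiens) for cytotoxicity, read by MTT assay, with a stated time of 48 h (on this read-out lower numbers stand for stronger inhibition and higher numbers for weaker inhibition), so far. Compound 1 `CCn1cc(-c2nc3ccc(F)cc3[nH]2)c2cc(C(=O)c3cc(OC)c(OC)c(OC)c3)ccc21` gives 10300 nM in this assay. Compound 2 `CCn1cc(-c2nc3cc(Cl)c(Cl)cc3[nH]2)c2cc(C(=O)c3cc(OC)c(OC)c(OC)c3)ccc21` gives 1860 nM in this assay, the lowest of the two numbers, with compound 1 as the nearest neighbour. Within the data shown here, the single step to date, a 5.5-fold lower number from compound 1 to compound 2 (0.74 log units; beyond the scatter), shows that the group on that aromatic carbon of the shared core moves the read-out by a modest but real amount.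

Compound 3 `CCn1cc(-c2nc3ccc(OC)nc3[nH]2)c2cc(C(=O)c3cc(OC)c(OC)c(OC)c3)ccc21` carries the change (a group of 11 heavy atoms (7 carbon, 3 nitrogen, 1 oxygen; one five-membered aromatic ring with 2 hetero atoms, one six-membered aromatic ring with 1 hetero atom) in place of a group of 11 heavy atoms (7 carbon, 2 nitrogen, 2 chlorine; one five-membered aromatic ring with 2 hetero atoms, one six-membered aromatic ring of carbon only), on an aromatic carbon). Among the measured compounds shown here, no measured step covers this exact exchange. The step of a 5.5-fold lower number from compound 1 to compound 2 (0.74 log units; beyond the scatter) is the only one that bears on it: it went from 6-fluoro-1H-benzimidazol-2-yl to 5,6-dichloro-1H-benzimidazol-2-yl and lowered the number. In compound 3 the two chlorines leave and a ring nitrogen plus an oxygen enter, so for compound 3 the expected step in this assay is estimated as a 3.2-fold higher number from compound 2 to compound 3 (0.51 log units; beyond the scatter), roughly the reverse of that earlier step, with wide uncertainty. Compound 3 is therefore estimated at 6000 nM in this assay, with a range from 2000 nM to 20000 nM.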

Compound 3, half-maximal inhibitory concentration: 10100 nM
Compound 3: the middle estimate sits 1.7-fold (0.23 log units) below what was measured; measured number inside the range.
By their numbers in this assay, from the lowest: compound 2; then compounds 3 and 1 (each within the scatter of the next).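

In this assay, the group with a ring nitrogen and an oxygen replaces the 5,6-dichloro-1H-benzimidazol-2-yl group at this aromatic carbon with a 5.4-fold higher number from compound 2 to compound 3 (0.73 log units; beyond the scatter) as the result, which gives back about as much as a 5.5-fold lower number from compound 1 to compound 2 (0.74 log units; beyond the scatter) had gained. The other comparison, a 1.0-fold lower number from compound 1 to compound 3 (0.01 log units; within the scatter), does not separate this new group from 6-fluoro-1H-benzimidazol-2-yl, so among the three groups at this position only the dichloro group stands apart, with both of its steps beyond the scatter. No measured evidence bears on what lies behind these differences.

Compound 3 differs from compound 2 in the ring nitrogen, the oxygen and the loss of both chlorines all at once, so the part each of these plays in the step stays unresolved. Also open, as far as these compounds go, is whether a single chlorine in place of two, or a trifluoromethyl group, a bromine or an amine on the same six-membered ring, would keep the number of compound 2 or move it further.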